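Swapping the amide group on compound 3

A few compounds are considered here, and "the series" means these few. Any claim that something is new, unique, unknown or untested is made for them only; others in the source may bear on it.

- compound 1 `COc1cc(N2CCC(C(=O)N3CCC(N(C)C)C3)CC2)ccc1Nc1nc(NC2CCCCC2)c2nc[nH]c2n1`: 60%
- compound 2 `COc1cc(N2CCC(C(=O)N3CCOCC3)CC2)ccc1Nc1nc(NC2CCCCC2)c2nc[nH]c2n1`: 70%
- compound 3 `COc1cc(N2CCC(CC(=O)N3CCN(C)CC3)CC2)ccc1Nc1nc(NC2CCCCC2)c2nc[nH]c2n1`: 43%

These three numbers come from an ADME assay on microsomes from liver (Mus musculus) for metabolic stability, read by mass spectrometry, with a stated time of 40 min, tested at 1 uM; a higher number here means that more of the compound is left, a lower number that less of the compound is left. Compound 3 has the lowest number of the three, and its gaps to the other two lie beyond the usual scatter.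

The next compound is compound 4 `COc1cc(N2CCC(CC(=O)N3CCC(N(C)C)C3)CC2)ccc1Nc1nc(NC2CCCCC2)c2nc[nH]c2n1`, which has 3-(dimethylamino)pyrrolidin-1-yl in place of 4-methylpiperazin-1-yl on a carbonyl carbon whose other neighbour is a saturated chain carbon. Counted out, the difference is 3-(dimethylamino)pyrrolidin-1-yl in place of 4-methylpiperazin-1-yl on a carbonyl carbon.

Among the compounds with values here, no measured pair makes exactly this swap. The closest case also exchanges one group on a carbonyl carbon, morpholin-4-yl for 3-(dimethylamino)pyrrolidin-1-yl, and it gave a number 10 percentage points higher from compound 1 to compound 2 (within the scatter). Two larger steps are a number 17 percentage points lower from compound 1 to compound 3 (beyond the scatter) and a number 27 percentage points lower from compound 2 to compound 3 (beyond the scatter). Both are modest, but each replaces the whole group on a saturated ring carbon, so they include more than the swap at hand and are weaker guides.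

The closest case therefore suggests no step beyond the scatter. The estimated change is a number 3 percentage points higher from compound 3 to compound 4 (within the scatter), which is expected to be small. Compound 4 is estimated at 46%, with an expected range from 31% to 61%.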

Compound 4, percent of the compound remaining: 48%
Compound 4: the middle estimate sits 2 percentage points below what was measured; low and high end bracket the measured number.
By their numbers in this assay, from the lowest: compounds 3 and 4 (each within the scatter of the next); then compounds 1 and 2 (each within the scatter of the next).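

With the carbonylmethyl link held fixed, a number 5 percentage points higher from compound 3 to compound 4 (within the scatter) in this assay, so at this carbonyl carbon, 3-(dimethylamino)pyrrolidin-1-yl and 4-methylpiperazin-1-yl cannot be told apart in this measure. The clearer change lies on the saturated ring carbon: keeping the same amine group while going from the carbonyl to the carbonylmethyl group gave a number 12 percentage points lower from compound 1 to compound 4 (beyond the scatter) and is the cleanest view yet of that difference, while the comparison with the morpholine amide gave a number 22 percentage points lower from compound 2 to compound 4 (beyond the scatter) and changes the amine group as well. Nothing measured here explains why either of these steps occurs.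

Going by these compounds, it remains open whether morpholin-4-yl on the carbonylmethyl group would give a number close to those of compound 3 and compound 4, or one closer to that of compound 2, which would show whether the link or the amine group matters more. On these data alone, how a longer chain carrying the carbonyl on the saturated ring carbon, or a carboxylic acid in place of the amide, would behave in this assay also remains open.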